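Lengthening a Methyl Chain to Decyl: Expected Half-Life

This account rests on a few compounds, and the source may have more. Where it says the series, first, only, none or still open, it means among the compounds named here.

Values measured so far in a physicochemical assay for metabolic stability, read by HPLC, tested at 2 mM; on this read-out higher numbers stand for a longer-lived compound and lower numbers for a shorter-lived compound
- Compound 1 `CCCCCCCCCc1ccc(OP(=O)(O)OC[C@H]2O[C@@H](n3cc(F)c(=O)[nH]c3=O)C[C@@H]2OC(=O)c2ccccc2)cc1` gives > 120 h as a limit of the assay, not a number
- Compound 2 `O=C(O[C@H]1C[C@H](n2cc(F)c(=O)[nH]c2=O)O[C@@H]1COP(=O)(O)Oc1ccc2ncccc2c1)c1ccccc1` gives 7.7 h
- Compound 3 `C[n+]1cccc(OP(=O)([O-])OC[C@H]2O[C@@H](n3cc(F)c(=O)[nH]c3=O)C[C@@H]2OC(=O)c2ccccc2)c1` gives 14.8 h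

The numbers for compound 2 and compound 3 lie within the usual scatter of repeated measurements, so neither can be ranked over the other. Compound 1 also carries a nonyl group, and its reading is a limit (the limit of > 120 h in this assay, at which 1 of the 3 values shown sits).

Compound 4 `CCCCCCCCCC[n+]1cccc(OP(=O)([O-])OC[C@H]2O[C@@H](n3cc(F)c(=O)[nH]c3=O)C[C@@H]2OC(=O)c2ccccc2)c1` is built from compound 3 by lengthening one chain. The change (nonyl in place of hydrogen on a saturated chain carbon bound to an aromatic nitrogen) puts nonyl in place of hydrogen on a saturated chain carbon bound to an aromatic nitrogen, which turns methyl into decyl.

Going by the values given here, no two measured compounds differ in one place only, so no measured step shows the size of this change. With compound 3 (14.8 h) as the starting point, a small move towards a longer life is expected in this assay and it may stay within the scatter. The expected range stays wide on the long side in view of compound 1 (> 120 h), whose value is a limit. In numbers, the estimate is a modest step (a 1.5-fold higher number from compound 3 to compound 4 (0.17 log units; within the scatter)). For compound 4 the estimated value is 22 h (expected range from 9 h to 70 h).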

Compound 4, half-life: 16.5 h
Estimate against measurement, compound 4: 1.3-fold (0.12 log units) above, and the stated range covers the measured number.
By their numbers in this assay, from the lowest: compounds 2, 3 and 4 (each within the scatter of the next, the first and the last beyond it). At a limit, above all of these: compound 1.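

In this assay the swap of nonyl for hydrogen on a saturated chain carbon bound to an aromatic nitrogen, which turns methyl into decyl, comes out as a 1.1-fold higher number from compound 3 to compound 4 (0.05 log units; within the scatter) and so cannot be told apart from no change at all. This is the first pair among the compounds shown that differs in one place only, which means the size of this change is now measured rather than guessed from compounds that differ in several places, and at this position a chain of nine extra carbons leaves the half-life where it was. The reading for compound 4 is a true number that can be compared directly, while the one value that is a limit and not a number belongs to compound 1: the limit of > 120 h in this assay, at which 1 of the 4 values shown sits.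

One step at a single position says nothing about the chains in between, such as butyl or hexyl, or about a longer chain such as hexadecyl. It also leaves open whether a chain ending in an amine or a carboxylic acid at this same place would read the same way, and whether the decyl chain would behave alike on another core.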